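Methoxy in place of chloro: a small step expected

A few compounds are considered here, and "the series" means these few. Any claim that something is new, unique, unknown or untested is made for them only; others in the source may bear on it.

In a functional assay on Jurkat cells (Homo sapiens) for cytotoxicity, read by MTT assay, with a stated time of 72 h (on this read-out higher numbers stand for weaker inhibition and lower numbers for stronger inhibition), compound 1 `O=C(Nc1ccccc1)Nc1ccc(C(=O)NO)cc1` gives 2500 nM, and compound 2 `O=C(Nc1ccc(Cl)cc1)Nc1ccc(C(=O)NO)cc1` gives 1060 nM, the lower of the two numbers. Compound 3 `COc1ccc(NC(=O)Nc2ccc(C(=O)NO)cc2)cc1` carries methoxy in place of chloro on an aromatic carbon, para to a large group: methoxy in place of chloro on an aromatic carbon. For the measured compounds named here, the only measured step bearing on this is modest: a 2.4-fold lower number from compound 1 to compound 2 (0.37 log units; beyond the scatter), for chloro in place of hydrogen on an aromatic carbon. Methoxy has not been measured at this place, so only a small rise, not beyond the scatter, is expected in this assay: a 1.6-fold higher number from compound 2 to compound 3 (0.21 log units; within the scatter). For compound 3 the estimated value is 1700 nM, with an expected range of 700 nM to 3800 nM.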

Compound 3, half-maximal inhibitory concentration: 8030 nM
Estimate against measurement, compound 3: 4.7-fold (0.67 log units) below; the measured number lies above the stated range.
By their numbers in this assay, from the lowest: compound 2; then compound 1; then compound 3.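

Methoxy on an aromatic carbon, para to a large group, gives a 7.6-fold higher number from compound 2 to compound 3 (0.88 log units; beyond the scatter) in this assay when it replaces chloro and a 3.2-fold higher number from compound 1 to compound 3 (0.51 log units; beyond the scatter) when it replaces hydrogen. This place therefore responds in both directions: chloro lowers the number relative to hydrogen, whereas methoxy raises it. Nothing measured here explains this difference between the two groups.

As far as these compounds go, whether an amine, a carboxylic acid or a longer chain such as ethoxy at this place would track chloro or methoxy remains open. So does whether methoxy would raise the number elsewhere on this ring.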